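Swapping an Aryl Amide for a Dimethylaminoethyl Amide

The compounds below may be only part of what the source reports. "The series", "measured", "known", "first", "only" and "open" are said of these compounds alone.

In an ADME assay on L02 cells (Homo sapiens) for cytotoxicity, read by MTT assay, with a stated time of 72 h (a higher number here means a weaker inhibitor, a lower number a stronger inhibitor), compound 1 `Cc1ccccc1NC(=O)CCC(=O)OCCCCCCSc1ccc([N+](=O)[O-])c2nonc12` gives 9490 nM, compound 2 `Cc1ccc(NC(=O)CCC(=O)OCCCCCCSc2ccc([N+](=O)[O-])c3nonc23)cc1` gives 7320 nM and compound 3 `COc1ccc(NC(=O)CCC(=O)OCCCCCCSc2ccc([N+](=O)[O-])c3nonc23)cc1` gives 8170 nM, which places compound 3 level with the other two within the scatter. Compound 4 `CN(C)CCNC(=O)CCC(=O)OCCCCCCSc1ccc([N+](=O)[O-])c2nonc12` has 2-(dimethylamino)ethyl in place of 4-methoxyphenyl on an amide-type nitrogen. Going by the values given here, three measured steps bear on this change: a 1.3-fold lower number from compound 1 to compound 2 (0.11 log units; within the scatter), a 1.2-fold lower number from compound 1 to compound 3 (0.07 log units; within the scatter) and a 1.1-fold higher number from compound 2 to compound 3 (0.05 log units; within the scatter). Each keeps an aromatic ring on that nitrogen, whereas this change removes it, so they offer only limited guidance. No shift beyond the scatter is expected in this assay, and the expected step is a 1.0-fold lower number from compound 3 to compound 4 (0.01 log units; within the scatter). Compound 4 is estimated at 8000 nM, with an expected range of 3000 nM to 20000 nM.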

Compound 4, half-maximal inhibitory concentration: 5980 nM
Estimate against measurement, compound 4: 1.3-fold (0.13 log units) above; the range from low to high includes it.
By their numbers in this assay, from the lowest: compounds 4, 2, 3 and 1 (each within the scatter of the next).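

In this assay, the aromatic ring on the amide-type nitrogen gives way to the ringless 2-(dimethylamino)ethyl with every step within the scatter (a 1.4-fold lower number from compound 3 to compound 4 (0.14 log units; within the scatter); a 1.2-fold lower number from compound 2 to compound 4 (0.09 log units; within the scatter); a 1.6-fold lower number from compound 1 to compound 4 (0.20 log units; within the scatter)). Among these four compounds, then, the number stays level whether this nitrogen carries an aryl group or a chain ending in an amine. Nothing measured here explains that result. Still open, from the compounds shown here alone, is whether a carboxylic acid, a morpholine ring or a longer chain on this nitrogen would also stay level with these compounds.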